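Working notes: bromo in place of ethyl

The compounds below may be only part of what the source reports. "The series", "measured", "known", "first", "only" and "open" are said of these compounds alone.

Measured so far in a functional assay on M21 cells (Homo sapiens) for antiproliferative activity, read by sulforhodamine B assay, with a stated time of 48 h (a higher number here means a weaker inhibitor, a lower number a stronger inhibitor), as follows
compound 1 `O=C1NCCN1c1ccc(S(=O)(=O)Nc2ccccc2)cc1` gives 200 nM
compound 2 `CCc1cccc(NS(=O)(=O)c2ccc(N3CCNC3=O)cc2)c1` gives 82 nM

Among the measured compounds shown here, compound 2 at 82 nM has the lower of the two numbers so far, and its gap to compound 1 lies beyond the scatter. The next compound, compound 3 `O=C1NCCN1c1ccc(S(=O)(=O)Nc2cccc(Br)c2)cc1`, is not yet measured. It carries bromo in place of ethyl on an aromatic carbon and otherwise keeps the core of compound 2. For the measured compounds named here, only one measured step bears on this change, a 2.4-fold lower number from compound 1 to compound 2 (0.39 log units; beyond the scatter) for ethyl in place of hydrogen on an aromatic carbon, and that step is modest. No measured compound carries bromo, so the size of a bromo effect is not shown directly. Bromo is therefore expected to behave more like ethyl than like hydrogen, though this is an expectation only, with no firm direction. The estimated change is a 1.2-fold higher number from compound 2 to compound 3 (0.09 log units; within the scatter) and no step beyond the scatter is expected. In this assay compound 3 is estimated at 100 nM with an expected range from 45 nM to 220 nM once measured.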

Compound 3, half-maximal inhibitory concentration: 59 nM
Compound 3: the middle estimate sits 1.7-fold (0.23 log units) above what was measured; measured number inside the range.
By their numbers in this assay, from the lowest: compounds 3 and 2 (each within the scatter of the next); then compound 1.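

In this assay, the aromatic carbon meta to a large group now holds two different groups that each give a lower number than hydrogen: alongside the earlier ethyl step, bromo gives a 3.4-fold lower number from compound 1 to compound 3 (0.53 log units; beyond the scatter) and this step lies beyond the scatter. Exchanging one group for the other gives a 1.4-fold lower number from compound 2 to compound 3 (0.14 log units; within the scatter) and stays within the scatter, so this assay does not separate bromo, with one heavy atom, from ethyl, with two carbons, at this place. No accompanying measurement bears on what lies behind these numbers.

The compounds shown leave open whether a longer chain, a methoxy group, an amine or a carboxylic acid at this place would fit with ethyl and bromo or would move the number away from them. They also leave open whether bromo or ethyl would give similar steps elsewhere on this aromatic ring, and whether the steps seen on the core of compound 1 would carry over to any other cell line.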